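Changing the Amine at the End of a Side Chain

A few compounds are considered here, and "the series" means these few. Any claim that something is new, unique, unknown or untested is made for them only; others in the source may bear on it.

Of the compounds shown here, three built on one shared core have been tested in a functional assay on MCF7 cells (Homo sapiens) for antiproliferative activity; a lower number here means a stronger inhibitor, a higher number a weaker inhibitor. Compound 1 `CC(C)=CCc1cc(C(=O)Nc2cc3ccc(OCC4CCCNC4)c(C)c3oc2=O)ccc1O` gives 790 nM. Compound 2 `CC(C)=CCc1cc(C(=O)Nc2cc3ccc(OCCCN4CCCC4)c(C)c3oc2=O)ccc1O` gives 990 nM. Compound 3 `CC(C)=CCc1cc(C(=O)Nc2cc3ccc(OCCCN(C(C)C)C(C)C)c(C)c3oc2=O)ccc1O` gives 1310 nM, the highest of the three numbers, yet still within the scatter of both others: a 1.7-fold higher number from compound 1 to compound 3 (0.22 log units; within the scatter) and a 1.3-fold higher number from compound 2 to compound 3 (0.12 log units; within the scatter). Compound 4 `CC(C)=CCc1cc(C(=O)Nc2cc3ccc(OCCCN(C)Cc4ccccc4)c(C)c3oc2=O)ccc1O` has not been measured; it differs from compound 3 by benzyl(methyl)amino in place of diisopropylamino on a saturated chain carbon, three bonds along the chain from an oxygen on an aromatic ring. The most relevant earlier step, a 1.3-fold higher number from compound 2 to compound 3 (0.12 log units; within the scatter), also exchanged one amine for another at this place and stayed within the scatter, as did a 1.3-fold higher number from compound 1 to compound 2 (0.10 log units; within the scatter). The expected step of a 1.1-fold lower number from compound 3 to compound 4 (0.04 log units; within the scatter) in this assay is therefore none beyond the scatter. Compound 4 is estimated at 1200 nM, with a likely range from 500 nM to 3000 nM.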

Compound 4, half-maximal inhibitory concentration: 11500 nM
Estimate against measurement, compound 4: 9.6-fold (0.98 log units) below, outside the stated range (above it).
By their numbers in this assay, from the lowest: compounds 1, 2 and 3 (each within the scatter of the next); then compound 4.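

Within the data shown here, until this result, exchanging the amine on this side chain had stayed within the scatter, but in this assay benzyl(methyl)amino gives an 8.8-fold higher number from compound 3 to compound 4 (0.94 log units; beyond the scatter) and a 12-fold higher number from compound 2 to compound 4 (1.07 log units; beyond the scatter) and also a 15-fold higher number from compound 1 to compound 4 (1.16 log units; beyond the scatter) as steps beyond it. This position therefore does respond to the group it carries, and the entering group alone among these amines holds a six-membered aromatic ring of carbon only. Nothing available on these compounds explains the rise.

On these data alone, whether that aromatic ring matters remains open: cyclohexyl(methyl)amino, with a saturated ring in its place, would help separate the ring's aromatic character from its size.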